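From compound 1 to compound 4: expected cytotoxicity

The source may hold more compounds than are shown below. What is called first, only, known or untested is meant among the compounds shown, and "the series" means these compounds.

Compound 1 `Cc1nc(C)c(Cn2ncc3c(Nc4ccc(OC(F)(F)F)cc4)ncnc32)s1` — > 10000 nM in an ADME assay on BaF3 cells (Mus musculus) for cytotoxicity; a lower number here means that less compound is needed, a higher number that more compound is needed for the effect
Compound 2 `NS(=O)(=O)c1ccc(-c2cc(Nc3ccc(OC(F)(F)F)cc3)ncn2)cc1` — > 10000 nM
Compound 3 `CC(C)Cn1cc(-c2cc(Nc3ccc(OC(F)(F)F)cc3)ncn2)cn1` — > 10000 nM

Among the measured compounds shown here, the three compounds measured so far share one feature: in this assay none of them reaches the half-maximal effect within the concentrations tested, so each value is a limit of the assay rather than a measured number. Compound 1 stands exactly where the other two stand, at the limit of > 10000 nM in this assay, at which 3 of the 3 values shown sit. No ordering among compounds 1, 2 and 3 can therefore be read from these numbers.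

Compound 4 `CCCn1ncc2c(Nc3ccc(OC(F)(F)F)cc3)ncnc21` is not yet measured. It differs from compound 1 in one place: ethyl in place of 2,4-dimethyl-1,3-thiazol-5-yl on a saturated chain carbon bound to an aromatic nitrogen. For the measured compounds named here, no step between two measured compounds is available to show how such a change moves this read-out, and the three limits give no number to start from. Since compound 1 itself sits at the limit of > 10000 nM in this assay, at which 3 of the 3 values shown sit, the expectation is that compound 4 also shows no measurable cytotoxicity within the tested range, so the step that the limit leaves unreadable from compound 1 to compound 4 is expected to be none beyond the scatter. The estimate for compound 4 in this assay is 15000 nM, with a range from 6000 nM to 50000 nM, most likely reported again only as a limit.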

Compound 4, half-maximal effective concentration: 6600 nM
Compound 4: middle estimate off by 2.3-fold (0.36 log units), on the high side, and the stated range covers the measured number.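

In this assay compound 4 gives a true number, 6600 nM, the first among the compounds shown, and so this read-out can be measured on this series at all. Compound 1 gives only a limit, > 10000 nM. Putting ethyl in place of 2,4-dimethyl-1,3-thiazol-5-yl on a saturated chain carbon bound to an aromatic nitrogen gives an at least 1.5-fold lower number from compound 1 to compound 4 (0.18 log units; that floor lies within the scatter), which shows that a change at this place can bring the read-out into the measurable range, while the true size of the step stays hidden behind the limit and the floor alone does not separate the two compounds.

The compounds shown leave open whether it is the loss of the ring or the short chain itself that matters here, and whether a longer chain, or a chain ending in an amine or a carboxylic acid, would move the number further in either direction. Any such trend would have little to rest on so far, as most of the values remain limits: the limit of > 10000 nM in this assay, at which 3 of the 4 values shown sit.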